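This account rests on a few compounds, and the source may have more. Where it says the series, first, only, none or still open, it means among the compounds named here.

Compound 1 `COc1cc(C(=O)c2sc3ccccc3c2-c2ccc(Cl)cc2)cc(OC)c1OC`: 3700 nM
Compound 2 `COc1ccc(-c2c(C(=O)c3cc(OC)c(OC)c(OC)c3)sc3ccccc23)cc1C`: > 10000 nM

In a functional assay on Jurkat cells (Homo sapiens) for antiproliferative activity, read by MTT assay, with a stated time of 72 h (on this read-out lower numbers stand for stronger inhibition and higher numbers for weaker inhibition), compound 2 gives only a limit, > 10000 nM, and no number. Compound 3 `COc1cc(C(=O)c2sc3ccccc3c2Nc2ccc(Cl)cc2)cc(OC)c1OC` differs from it by (4-chlorophenyl)amino in place of 4-methoxy-3-methylphenyl on an aromatic carbon, with (4-chlorophenyl)amino in place of 4-methoxy-3-methylphenyl on an aromatic carbon. Among the compounds with values here, one measured step bears on this: an at least 2.7-fold higher number from compound 1 to compound 2 (0.43 log units; beyond the scatter), beyond the scatter. Within the data shown here, it is the same exchange site, though no measured step covers the amino link. A move back toward compound 1 at 3700 nM is therefore expected, to a lower number, of at least modest size. The expected step is an at least 3.3-fold lower number from compound 2 to compound 3 (0.52 log units; beyond the scatter). Compound 3 is estimated at 3000 nM, with an expected range of 500 nM to 10000 nM.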

Compound 3, half-maximal inhibitory concentration: 1900 nM
Estimate against measurement, compound 3: 1.6-fold (0.20 log units) above; measured number inside the range.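

In this assay, the amino link is accepted at this position: with the 4-chlorophenyl ring kept, the exchange gives a 1.9-fold lower number from compound 1 to compound 3 (0.29 log units; within the scatter). Against 4-methoxy-3-methylphenyl, (4-chlorophenyl)amino gives an at least 5.2-fold lower number from compound 2 to compound 3 (0.72 log units; beyond the scatter), so the weak end of this small set is set by compound 2 alone among the groups shown. The size of that step is open at the top, as compound 2 gives a limit and not a number: the limit of > 10000 nM in this assay, at which 1 of the 3 values shown sits.

Open, going by these compounds, is whether the amino hydrogen matters, which a methylated amino link would test. Also open, on these data alone, is whether a (4-methoxy-3-methylphenyl)amino group would stay level with compound 3.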